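A few compounds are considered here, and "the series" means these few. Any claim that something is new, unique, unknown or untested is made for them only; others in the source may bear on it.

Measured compounds:
- compound 1 `COc1ccc(Cn2nc(-c3ccccc3)c3cc(C(=N)Nc4cccc(C(F)(F)F)c4)nc(NC4CCCCC4)c32)cc1`, "not determined" (no result reported)
- compound 2 `CN1CCN(c2ccc(NC(=N)c3cc4cnn(C)c4cn3)cc2)CC1`, 24000 nM
- compound 3 `COc1ccc(Cn2nc(-c3ccccc3)c3cc(C(=N)Nc4cccc(C(F)(F)F)c4)nc(Nc4cc(OC)c(OC)c(OC)c4)c32)cc1`, "not determined" (no result reported)

Compound 1 has no single number in a functional assay on HT-1080 cells (Homo sapiens) for cytotoxicity, read by MTT assay, with a stated time of 72 h; a lower number here means a stronger inhibitor, a higher number a weaker inhibitor; its entry is recorded as "not determined" (no result reported), and compound 3, which shares the same core, likewise stands at "not determined" (no result reported). The only figure in this assay belongs to compound 2, built on a different core, which gives 24000 nM. Compound 1 therefore stands without a measured position, and no comparison with compound 2 can be drawn from the structures alone.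

Compound 4 `COc1ccc(Cn2nc(-c3ccccc3)c3cc(C(=N)Nc4cccc(C(F)(F)F)c4)ncc32)cc1` differs from compound 1 in one place: hydrogen in place of cyclohexylamino on an aromatic carbon. For the measured compounds named here, no step between measured compounds with this change is available. Without such a reference, the writer expects the step from compound 1 to compound 4 to be small, not beyond the usual scatter, in either direction. The only anchor is compound 2 at 24000 nM, which sets the scale of what this series has shown so far.

Compound 4 is estimated to give 12000 nM in this assay, within a range from 1500 nM to 60000 nM.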

Compound 4, half-maximal inhibitory concentration: 46700 nM
Compound 4: the middle estimate sits 3.9-fold (0.59 log units) below what was measured; low and high end bracket the measured number.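

In this assay compound 4 gives 46700 nM, but compound 1 has no single number, so no step can be read between compound 1 and compound 4. The compounds shown leave open what cyclohexylamino contributes on the shared core. No supporting data bear on this result.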